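Fluoro for chloro on the benzylsulfanyl arm

The source may report more compounds than this note shows. Statements on the series, on what has been measured and on what is new or still open speak of the compounds shown alone.

Measured compounds:
compound 1, `COc1ccccc1/C=C(/SCc1ccc(Cl)cc1)C(=O)c1ccc(Cl)cc1`, 1000 nM
compound 2, `COc1ccc(/C=C(/SCc2ccc(Cl)cc2)C(=O)c2ccc(Br)cc2)cc1`, 10000 nM
compound 3, `COc1ccc(/C=C(/SCc2ccc(F)cc2)C(=O)c2ccc(Br)cc2)cc1`, 50000 nM

Of the compounds shown here, three have been tested in a functional assay on DU-145 cells (Homo sapiens) for inhibition, read by trypan blue exclusion, with a stated time of 96 h; a higher number here means a weaker inhibitor of growth, a lower number a stronger inhibitor of growth. Compound 1 gives 1000 nM, the lowest of the three numbers. Compound 2 gives 10000 nM, and compound 3 gives 50000 nM. Compound 1 and compound 2 differ in more than one place, so the difference between the two cores is not broken down here; their values simply show that compound 2 sits higher than compound 1 by a margin beyond the scatter.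

Compound 2 and compound 3 differ in one place, (fluoro in place of chloro on an aromatic carbon), and this change produced a 5.0-fold higher number from compound 2 to compound 3 (0.70 log units; beyond the scatter).

Compound 4, `COc1ccccc1/C=C(/SCc1ccc(F)cc1)C(=O)c1ccc(Cl)cc1`, has not yet been measured in this assay . It differs from compound 1 in the same way, (fluoro in place of chloro on an aromatic carbon), and the surroundings of the place are described in the same words for both pairs. Within the data shown here, since the one measured instance of this change, from compound 2 to compound 3, gave a 5.0-fold higher number from compound 2 to compound 3 (0.70 log units; beyond the scatter), a step of similar size is expected from compound 1 to compound 4, namely a 5.0-fold higher number from compound 1 to compound 4 (0.70 log units; beyond the scatter). This expectation rests on a single pair and on compound 1 giving 1000 nM, so it carries real uncertainty. Compound 4 is therefore estimated at 5000 nM, expected to lie between 1500 nM and 15000 nM.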

Compound 4, concentration for 50% growth inhibition: 10000 nM
The estimate for compound 4 lay 2.0-fold (0.30 log units) below the measured number, within the range that was stated.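

In this assay the replacement of (4-chlorobenzyl)sulfanyl by (4-fluorobenzyl)sulfanyl also raised the number on the core of compound 1, giving a 10-fold higher number from compound 1 to compound 4 (1.00 log units; beyond the scatter). Set beside the earlier instance, the change went the same way on both cores, and the two steps do not differ by more than repeated measurements would allow: the same change on two cores in this assay, a 5.0-fold higher number (0.70 log units; beyond the scatter) from compound 2 to compound 3 and a 10-fold higher number (1.00 log units; beyond the scatter) from compound 1 to compound 4, 2.0-fold (0.30 log units) apart, within the scatter of two such steps. This shows that, within these two pairs, the step carried from one core to the other in both direction and approximate size, but two pairs make no rule for the wider series, and they do not show why the fluoro compounds give the higher numbers or whether the step would hold on a third core.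

The compounds shown leave open how other groups would behave at this same place on the aromatic ring, such as a methyl, a trifluoromethyl or a nitrile in place of the chloro. On these data alone, they also leave unseparated the contributions of the several places in which the two cores differ, so the effect of any one of those places on growth inhibition remains unknown.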